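The compounds below may be only part of what the source reports. "The series", "measured", "known", "first", "only" and "open" are said of these compounds alone.

Among the measured compounds shown here, in a physicochemical assay for lipophilicity (on this read-out lower numbers stand for lower lipophilicity and higher numbers for higher lipophilicity), two compounds sharing one core have numbers so far. Compound 1 `COc1cc(Cn2c(=O)cc(N3CCC[C@@H](N)C3)n(Cc3cc(F)ccc3C#N)c2=O)c(Br)c(Br)c1OC` gives 4.32, and compound 2 `CCCCCCn1c(=O)cc(N2CCC[C@@H](N)C2)n(Cc2cc(F)ccc2C#N)c1=O` gives 3.26, the lower of the two. Compound 3 `CCCCCCCCCCn1c(=O)cc(N2CCC[C@@H](N)C2)n(Cc2cc(F)ccc2C#N)c1=O` has not yet been measured. It differs from compound 2 in one place, butyl in place of hydrogen on a saturated chain carbon, six bonds along the chain from an aromatic nitrogen. For the measured compounds named here, no measured step isolates a change of this kind. The closest evidence is a number 1.06 log units lower from compound 1 to compound 2 (beyond the scatter), where pentyl takes the place of 2,3-dibromo-4,5-dimethoxyphenyl on a saturated chain carbon bound to an aromatic nitrogen. That step shows that this assay can move beyond the scatter with a change in this part of the molecule, but it gives no rate for each added chain carbon. The entering butyl brings only carbon, with no hydrogen-bond donors or acceptors, so a large rise is expected, probably exceeding the size of that one measured step. The expected change is a number 1.74 log units higher from compound 2 to compound 3 (beyond the scatter). For compound 3 the estimated value is 5, with an expected range of 4.4 to 5.6.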

Compound 3, partition coefficient: 4.93
Compound 3: middle estimate off by 0.07 log units, on the high side; low and high end bracket the measured number.
By their numbers in this assay, from the lowest: compound 2; then compound 1; then compound 3.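

In this assay, among the compounds shown here, the earlier compounds showed only pentyl taking the place of 2,3-dibromo-4,5-dimethoxyphenyl, so the chain length was never changed on its own. Compound 3 now isolates that change: butyl in place of hydrogen on a saturated chain carbon, six bonds along the chain from an aromatic nitrogen, gives a number 1.67 log units higher from compound 2 to compound 3 (beyond the scatter), and the entering group is carbon alone, with no ring and no hydrogen-bond donors or acceptors. The order against the substituted phenyl group also reverses, since nonyl in place of it gives a number 0.61 log units higher from compound 1 to compound 3 (beyond the scatter), whereas pentyl gave a lower number, and no measurement at hand explains why the read-out moves in this way.

For the compounds shown here, with only one such step, the compounds give no rate for each added chain carbon and do not show whether the rise would continue with a longer chain. From the compounds shown here alone, how an amine or a carboxylic acid carried on this chain would shift the number also remains open.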